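This account rests on a few compounds, and the source may have more. Where it says the series, first, only, none or still open, it means among the compounds named here.

Compound 1, `NS(=O)(=O)c1ccc(N2N=C(c3ccccc3)CC2c2ccccc2F)cc1`: 21000 nM in an ADME assay on BHK-21 cells (Mesocricetus auratus) for cytotoxicity, read by MTT assay, with a stated time of 72 h; a lower number here means that less compound is tolerated, a higher number that more compound is tolerated
Compound 2, `NS(=O)(=O)c1ccc(N2N=C(c3ccc(Oc4ccccc4)cc3)CC2c2ccccc2Cl)cc1`: 8000 nM
Compound 3, `Cc1cccc(C2CC(c3ccccc3)=NN2c2ccc(S(N)(=O)=O)cc2)c1`: 25000 nM

Among these three numbers compound 3 stands highest; compound 1 sits within the scatter of it, whereas compound 2 lies beyond the scatter below it. Compound 4, `NS(=O)(=O)c1ccc(N2N=C(c3ccccc3)CC2c2ccccc2Cl)cc1`, is not yet measured. It differs from compound 3 in one place: 2-chlorophenyl in place of 3-methylphenyl on a saturated ring carbon. Among the measured compounds shown here, the one measured step at that same saturated ring carbon, a 1.2-fold higher number from compound 1 to compound 3 (0.08 log units; within the scatter), stayed within the scatter. For the measured compounds named here, compound 2 also carries a 2-chlorophenyl group and gives the lowest number, yet it differs from compound 4 in a second place as well, so no single step isolates the chlorine. On the available evidence the expected step is a 1.4-fold lower number from compound 3 to compound 4 (0.14 log units; within the scatter), within the scatter. Compound 4 is therefore estimated at 18000 nM in this assay, with a range from 7000 nM to 40000 nM.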

Compound 4, half-maximal cytotoxic concentration: 13000 nM
Compound 4: the middle estimate sits 1.4-fold (0.14 log units) above what was measured; the measured number falls inside the stated range.
By their numbers in this assay, from the lowest: compounds 2, 4, 1 and 3 (each within the scatter of the next, the first and the last beyond it).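

In this assay, chloro in place of fluoro on an aromatic carbon gives a 1.6-fold lower number from compound 1 to compound 4 (0.21 log units; within the scatter) and 2-chlorophenyl in place of 3-methylphenyl gives a 1.9-fold lower number from compound 3 to compound 4 (0.28 log units; within the scatter), so both changes at this saturated ring carbon stay within the scatter. Hydrogen in place of phenoxy on an aromatic carbon, now isolated as a single change, gives a 1.6-fold higher number from compound 2 to compound 4 (0.21 log units; within the scatter) and also stays within the scatter. No measurement offered here explains these small steps. The compounds shown leave open whether an amine or a carboxylic acid in place of the aryl group on the saturated ring carbon would give a step beyond the scatter. They also leave open what a longer chain in place of phenoxy would do.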